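Side chain step from compound 2 to compound 3

The source may report more compounds than this note shows. Statements on the series, on what has been measured and on what is new or still open speak of the compounds shown alone.

Values so far in a functional assay (trachea) with Cavia porcellus as the target (on this read-out lower numbers stand for an effect already at smaller amounts and higher numbers for an effect only at larger amounts of compound), are these:
compound 1 (`CCCn1c(=O)n(CCC(=O)O)c(=O)c2[nH]cnc21`) gives 21200 nM as its value
compound 2 (`CCCn1c(=O)n(CC(C)=O)c(=O)c2[nH]cnc21`) gives 14900 nM as its value

Only these two numbers exist, and compound 2 stands level with compound 1 within the scatter. The next compound is compound 3 (`CCCn1c(=O)n(CCC(C)=O)c(=O)c2[nH]cnc21`), with 2-oxopropyl in place of acetyl on a saturated chain carbon bound to an aromatic nitrogen. For the measured compounds named here, one measured step bears on this place, namely a 1.4-fold lower number from compound 1 to compound 2 (0.15 log units; within the scatter) with acetyl in place of carboxymethyl. It stayed within the scatter, and one step is thin evidence. No step beyond the scatter is therefore expected in this assay, and no direction can be argued with confidence. The expected step is a 1.2-fold lower number from compound 2 to compound 3 (0.09 log units; within the scatter) on this estimate. Compound 3 is estimated at 12000 nM with an expected range of 5500 nM to 26000 nM in this read-out.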

Compound 3, half-maximal effective concentration: 3500 nM
For compound 3 the middle estimate is 3.4-fold (0.54 log units) above the measured one, outside the stated range (below it).
By their numbers in this assay, from the lowest: compound 3; then compounds 2 and 1 (each within the scatter of the next).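

In this assay this position now shows a step beyond the scatter, which the earlier pair did not: 2-oxopropyl in place of acetyl on a saturated chain carbon bound to an aromatic nitrogen gives a 4.3-fold lower number from compound 2 to compound 3 (0.63 log units; beyond the scatter) in a change that leaves the counted donors, acceptors and charge of the group as they were. Methyl in place of hydroxy on a carbonyl carbon gives a 6.1-fold lower number from compound 1 to compound 3 (0.78 log units; beyond the scatter) and is also beyond the scatter, so the end of this chain matters as well as the group attached to the aromatic nitrogen. Nothing available accounts for either step.

From the compounds shown here alone, whether a longer chain carrying the same carbonyl extends this trend or reverses it remains open. Also open, going by these compounds, is how an amide or an amine at the chain end would compare with the methyl ketone of compound 3.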